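Chloro for hydroxy on the aryl ketone of compound 2

The source may report more compounds than this note shows. Statements on the series, on what has been measured and on what is new or still open speak of the compounds shown alone.

Measured compounds:
compound 1 `COc1ccc(C(=O)/C=C/c2cc3ccccc3[nH]c2=O)cc1` – 1780 nM
compound 2 `O=C(/C=C/c1cc2ccccc2[nH]c1=O)c1ccc(O)cc1` – 4710 nM

Compound 2 `O=C(/C=C/c1cc2ccccc2[nH]c1=O)c1ccc(O)cc1` stands as the higher of the two numbers in a functional assay on CAKI-1 cells (Homo sapiens) for cytotoxicity, read by sulforhodamine B assay, with a stated time of 24 h; on this read-out lower numbers stand for stronger inhibition of growth and higher numbers for weaker inhibition of growth: compound 2 gives 4710 nM, whereas compound 1 `COc1ccc(C(=O)/C=C/c2cc3ccccc3[nH]c2=O)cc1` gives 1780 nM. For the measured compounds named here, the one measured step between them, a 2.6-fold higher number from compound 1 to compound 2 (0.42 log units; beyond the scatter), is the only guide available, and it runs in the opposite sense to the change now considered: there the hydroxy arrived and the number rose, here the hydroxy leaves again.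

Compound 3 `O=C(/C=C/c1cc2ccccc2[nH]c1=O)c1ccc(Cl)cc1` differs from compound 2 by chloro in place of hydroxy on an aromatic carbon. Going by the values given here, no measured pair exchanges a hydroxy for a chloro, so the expectation leans on the single step from compound 1 to compound 2 and on the fact that compound 3, like compound 1, carries no hydroxy at that position. A modest drop in the number toward the level of compound 1 is expected, without any claim to exceed it, since nothing here shows what chloro itself does.

The estimate for compound 3 in this assay is therefore 2200 nM, with a range from 800 nM to 6000 nM, which is expected to mean a step of a 2.1-fold lower number from compound 2 to compound 3 (0.33 log units; beyond the scatter).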

Compound 3, concentration for 50% growth inhibition: 1600 nM
Estimate against measurement, compound 3: 1.4-fold (0.14 log units) above; the range from low to high includes it.
By their numbers in this assay, from the lowest: compounds 3 and 1 (each within the scatter of the next); then compound 2.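

In this assay the change from 4-hydroxyphenyl to 4-chlorophenyl gives a 2.9-fold lower number from compound 2 to compound 3 (0.47 log units; beyond the scatter), which is beyond the scatter, so a second group in place of hydroxy now goes with a lower number, and this no longer rests on methoxy alone. Chloro and methoxy, which share no atom at the position, cannot be told apart here, with a 1.1-fold lower number from compound 1 to compound 3 (0.05 log units; within the scatter), which is within the scatter; among these three compounds, compound 2, the only one carrying hydroxy, therefore stands apart as the weakest, while the earlier pair could not show whether methoxy or hydroxy was the unusual group. No measurement at hand explains why the hydroxy compound differs from the other two.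

The three compounds cover only hydroxy, methoxy and chloro on a single carbon, para to a large group, and leave open whether an amine, a carboxylic acid or a fluoro in that place would fall with chloro and methoxy or with hydroxy. They also leave open whether the same pattern would hold with any of these groups on another carbon of that ring.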